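This account rests on a few compounds, and the source may have more. Where it says the series, first, only, none or still open, it means among the compounds named here.

In a functional assay on MCF7 cells (Homo sapiens) for antiproliferative activity, read by CellTiter-Glo, with a stated time of 5 days (on this read-out lower numbers stand for stronger inhibition and higher numbers for weaker inhibition), the measured compounds stand as follows
- Compound 1 `CC/C(=C(/c1ccc(/C=C/C(=O)O)cc1)c1ccc2[nH]ncc2c1)c1ccccc1` gives 7.2 nM
- Compound 2 `CC/C(=C(/c1ccc(/C=C/C(=O)O)cc1)c1ccc2nncn2c1)c1ccccc1` gives > 500 nM, which is a limit

Compound 2 thus has no number, only that limit of the assay. Compound 3 `CC/C(=C(/c1ccc(/C=C/C(=O)O)cc1)c1ccc2ccccc2c1)c1ccccc1` differs from it by one change, (a group of 10 heavy atoms (10 carbon; 2 six-membered aromatic rings of carbon only) in place of a group of 9 heavy atoms (6 carbon, 3 nitrogen; one five-membered aromatic ring with 3 hetero atoms, one six-membered aromatic ring with 1 hetero atom), on a double-bonded chain carbon bound to an aromatic carbon and a double-bonded chain carbon). Going by the values given here, the only measured step at this place is an at least 69-fold higher number from compound 1 to compound 2 (1.84 log units; beyond the scatter), large and beyond the scatter. Read backwards, that step points to a lower number in this assay, but compound 3 does not restore the group of compound 1, so only part of the step is expected to return. The expected step is an at least 3.3-fold lower number from compound 2 to compound 3 (0.52 log units; beyond the scatter). Compound 3 is estimated at 150 nM, within a range of 30 nM to 700 nM.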

Compound 3, half-maximal inhibitory concentration: 180 nM
For compound 3 the middle estimate is 1.2-fold (0.08 log units) below the measured one; the measured number falls inside the stated range.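

In this assay, naphthalen-2-yl at this place gives an at least 2.7-fold lower number from compound 2 to compound 3 (0.44 log units; beyond the scatter) and so yields a measured number where the group of compound 2 yields none. It does not take the place of 1H-indazol-5-yl, though, as a 25-fold higher number from compound 1 to compound 3 (1.40 log units; beyond the scatter) shows. Compound 2 has only a limit, so the first of these steps is a bound: the limit of > 500 nM in this assay, at which 1 of the 3 values shown sits.

The compounds shown leave open whether a 1H-indol-5-yl or an aminophenyl group at this place would come closer to compound 1 than naphthalen-2-yl does.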